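This account rests on a few compounds, and the source may have more. Where it says the series, first, only, none or still open, it means among the compounds named here.

The measured compounds and their numbers:

compound 1, `COc1cc(-c2nnc(SCC(=O)Nc3ccc(/C(C)=N/O)cc3)n2-c2ccccc2)cc(OC)c1OC`: 59%
compound 2, `C/C(=N\O)c1ccc(NC(=O)CSc2nnc(-c3ccccc3)n2-c2ccccc2)cc1`: 50%
compound 3, `COc1ccc(-c2nnc(SCC(=O)Nc3ccc(/C(C)=N/O)cc3)n2-c2ccccc2)cc1OC`: 57%

In a functional assay on the whole organism (strain albino) for inhibition, with Rattus norvegicus as the target, read by paw edema, with stated times of 30 min and 1 h, at a dose of 0.28 mmol/kg by the oral route (a higher number here means more inhibition at the dose given (going by the name of the read-out), a lower number less inhibition), compound 1 stands highest of the three numbers, but both of its neighbours sit within the scatter of it: a number 9 percentage points lower from compound 1 to compound 2 (within the scatter) and a number 2 percentage points lower from compound 1 to compound 3 (within the scatter) are small, as is a number 7 percentage points higher from compound 2 to compound 3 (within the scatter). All three steps vary the aryl group carried on a ring carbon of the shared core, and none of them moves the number beyond the scatter.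

Compound 4, `C=CCn1c(SCC(=O)Nc2ccc(/C(C)=N/O)cc2)nnc1-c1cc(OC)c(OC)c(OC)c1`, differs from compound 1 at a different site: allyl in place of phenyl on an aromatic nitrogen. Going by the values given here, no measured step varies the group on the aromatic nitrogen, so none of the three steps bears directly on this change. What the measured steps do show is that the series is flat across the changes that were made, so there is no basis in the data for expecting a large move in either direction. Compound 4 is therefore expected to land near compound 1, with a step of a number 6 percentage points lower from compound 1 to compound 4 (within the scatter) that is not beyond the scatter. The estimate for compound 4 is 53%, within a range of 36% to 68%.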

Compound 4, a percentage reported as inhibition, in the whole organism at one dose (the size of the read-out at that dose, not a potency): 49%
Beside the measured number, compound 4's estimate is 4 percentage points above it; the range from low to high includes it.
By their numbers in this assay, from the lowest: compounds 4, 2, 3 and 1 (each within the scatter of the next).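

Placing allyl in place of phenyl on the aromatic nitrogen gives, in this assay, a number 10 percentage points lower from compound 1 to compound 4 (within the scatter), and this is the first look at this position, since the earlier steps varied only the aryl group on a ring carbon. The change is also a larger one in make-up than those steps: a phenyl of 6 heavy atoms with its six-membered aromatic ring leaves, and an allyl of 3 heavy atoms with no ring enters, yet the number stays within the scatter. At this one dose, then, an aromatic ring on this nitrogen is not shown to be required, and the flatness seen across the aryl groups extends to this second site. No measurement shown offers an explanation for this step.

With only phenyl and allyl on this nitrogen, the compounds leave open how a benzyl group, a longer chain such as hexyl, or a chain ending in a carboxylic acid would read here. They also leave open whether allyl would read the same alongside the phenyl of compound 2 or the 3,4-dimethoxyphenyl of compound 3.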